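The source may report more compounds than this note shows. Statements on the series, on what has been measured and on what is new or still open speak of the compounds shown alone.

Three compounds of the series carry numbers in an assay on membranes from brain for binding affinity to Adrenergic receptor alpha-1 (Rattus norvegicus); on this read-out lower numbers stand for stronger inhibition and higher numbers for weaker inhibition. Compound 2 `O=[N+]([O-])c1ccc2[nH]c(Cc3ccc(Oc4ccccc4)cc3)nc2c1` gives 1200 nM, the lowest of the three numbers. Compound 1 `CS(=O)(=O)Nc1ccc2nc(CN3CCC(Cc4ccccc4)CC3)[nH]c2c1` gives 1500 nM, a number within the scatter of compound 2. Compound 3 `Oc1cccc2[nH]c(Cc3ccc(Oc4ccccc4)cc3)nc12` gives 5500 nM, a number that stands beyond the scatter from compound 2. Compound 4 `CCS(=O)(=O)Nc1ccc2[nH]c(Cc3ccc(Oc4ccccc4)cc3)nc2c1` has no number yet in this assay. Against compound 2 it shows ((ethylsulfonyl)amino in place of nitro on an aromatic carbon). Within the data shown here, no pair of measured compounds isolates this change, so nothing in the data fixes its size or direction. The expected step is a 1.3-fold higher number from compound 2 to compound 4 (0.10 log units; within the scatter), not clearly beyond the scatter in either direction. Compound 4 is therefore estimated at 1500 nM, with a range from 500 nM to 4500 nM.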

Compound 4, half-maximal inhibitory concentration: 2800 nM
Beside the measured number, compound 4's estimate is 1.9-fold (0.27 log units) below it, within the range that was stated.
By their numbers in this assay, from the lowest: compounds 2, 1, 4 and 3 (each within the scatter of the next, the first and the last beyond it).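

In this assay, among these compounds, (ethylsulfonyl)amino in place of nitro on this aromatic carbon gives a 2.3-fold higher number from compound 2 to compound 4 (0.37 log units; beyond the scatter), the first step that isolates one place. The change is modest, so this position still carries a sulfonyl-bearing group without a large shift in the number. Nothing available explains the direction of this step.

A single step cannot separate the contribution of the ethyl chain from that of the sulfonylamino link. As far as these compounds go, how an unsubstituted amine or a carboxylic acid would read at this position remains open.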